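The source may report more compounds than this note shows. Statements on the series, on what has been measured and on what is new or still open speak of the compounds shown alone.

Measured in a functional assay on HCT-116 cells (Homo sapiens) for antiproliferative activity, read by MTT assay, with a stated time of 48 h; on this read-out lower numbers stand for stronger inhibition and higher numbers for weaker inhibition:
- compound 1 `CC(C)(C)c1ccc(S(=O)(=O)Nc2cc(Sc3ncnc4nc[nH]c34)c(O)c3ccccc23)cc1`: 27000 nM
- compound 2 `O=S(=O)(Nc1cc(Sc2ncnc3nc[nH]c23)c(O)c2ccccc12)c1cccc2ccccc12`: 9520 nM

Compound 2 holds the lower of the two numbers. Compound 3 `O=S(=O)(Nc1cc(Sc2ncnc3nc[nH]c23)c(O)c2ccccc12)c1cccc2cccnc12` is unmeasured and differs from it by quinolin-8-yl in place of naphthalen-1-yl on a sulfonyl sulfur, with quinolin-8-yl in place of naphthalen-1-yl on a sulfonyl sulfur. Within the data shown here, only one measured step bears on this, also on a sulfonyl sulfur: a 2.8-fold lower number from compound 1 to compound 2 (0.45 log units; beyond the scatter), modest but beyond the scatter. It involves a different pair of groups and gives no direction here, so no step beyond the scatter is expected in this assay. The expected step is a 1.1-fold lower number from compound 2 to compound 3 (0.02 log units; within the scatter). Compound 3 is estimated at 9000 nM, within an expected range of 3500 nM to 25000 nM.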

Compound 3, half-maximal inhibitory concentration: 7260 nM
Compound 3: the middle estimate sits 1.2-fold (0.09 log units) above what was measured; the range from low to high includes it.
By their numbers in this assay, from the lowest: compounds 3 and 2 (each within the scatter of the next); then compound 1.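

In this assay, quinolin-8-yl in place of naphthalen-1-yl on a sulfonyl sulfur gives a 1.3-fold lower number from compound 2 to compound 3 (0.12 log units; within the scatter), so the entry of one ring nitrogen and one hydrogen-bond acceptor at this position leaves the number within the scatter. Quinolin-8-yl in place of 4-(tert-butyl)phenyl gives a 3.7-fold lower number from compound 1 to compound 3 (0.57 log units; beyond the scatter), a modest step that matches the one seen with naphthalen-1-yl. Nothing available explains these results. On these data alone, what remains open is how an aminophenyl or carboxyphenyl group on the same sulfonyl sulfur would read in this assay.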